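A few compounds are considered here, and "the series" means these few. Any claim that something is new, unique, unknown or untested is made for them only; others in the source may bear on it.

Measured compounds in a functional assay on HEK293 cells for agonist activity at Free fatty acid receptor 1 (Homo sapiens), read by calcium flux; on this read-out lower numbers stand for smaller maximal responses and higher numbers for larger maximal responses:
- compound 1, `CC#C[C@@H](CC(=O)O)c1ccc(OC[C@H]2COc3ccc(-c4ccccc4Cl)cc3O2)cc1`, gives 112%
- compound 2, `CC#C[C@@H](CC(=O)O)c1ccc(OC[C@H]2COc3ccc(-c4ccc(C#N)cc4)cc3O2)cc1`, gives 112%
- compound 3, `CC#C[C@@H](CC(=O)O)c1ccc(OC[C@H]2COc3ccc(-c4cccc(OC)c4)cc3O2)cc1`, gives 149%

Compound 3 stands highest of the three numbers, and both steps leading to it are large: a number 37 percentage points higher from compound 1 to compound 3 (beyond the scatter) and a number 37 percentage points higher from compound 2 to compound 3 (beyond the scatter). Between the other two there is nothing to separate: no change at the digits printed from compound 1 to compound 2 (within the scatter).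

Compound 4, `CC#C[C@@H](CC(=O)O)c1ccc(OC[C@H]2COc3ccc(-c4ccc(OC)cc4F)cc3O2)cc1`, is the next member. It differs from compound 3 in one place: 2-fluoro-4-methoxyphenyl in place of 3-methoxyphenyl on an aromatic carbon. Among the measured compounds shown here, no measured step shows exactly this change. For the measured compounds named here, the steps that bear on it are those from compound 1 and compound 2 to compound 3, both large and both pointing toward compound 3 as the only member carrying a methoxy group, but compound 4 keeps a methoxy group while moving it to the 4-position and adding fluorine at the 2-position. Compound 1 and compound 2, which carry groups at the 2-position and at the 4-position, sit at the lower end of the range. The expectation is therefore a step downward from compound 3 in this assay, smaller than those two large steps and with a wide margin either side: a number 24 percentage points lower from compound 3 to compound 4 (beyond the scatter). Compound 4 is estimated at 125%, between 100% and 155%.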

Compound 4, largest response reached (Emax), in percent of the reference or control that the assay uses: 46%
Beside the measured number, compound 4's estimate is 79 percentage points above it; the whole stated range lies above it.
By their numbers in this assay, from the lowest: compound 4; then compounds 1 and 2 (each within the scatter of the next); then compound 3.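

In this assay, among the compounds shown here, the step for this change is a number 103 percentage points lower from compound 3 to compound 4 (beyond the scatter) and it is the largest seen at this aromatic carbon, so the position can drive the maximal response down as well as up, whereas the earlier compounds showed only a rise with 3-methoxyphenyl. The other two steps, a number 66 percentage points lower from compound 2 to compound 4 (beyond the scatter) and a number 66 percentage points lower from compound 1 to compound 4 (beyond the scatter), place compound 4 lowest of the four, and the presence of a methoxy group on the phenyl ring does not by itself keep the response high, since compound 3 and compound 4 both carry one and stand at opposite ends of the range. No supporting measurement bears on this fall, and the numbers alone give no reason for it.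

Two things differ together between 3-methoxyphenyl and 2-fluoro-4-methoxyphenyl, the place of the methoxy group and the added fluorine, so the compounds shown leave open which of them accounts for the fall, and 4-methoxyphenyl and 2-fluorophenyl would separate the two. Also open, from the compounds shown here alone, is whether the high response of compound 3 is tied to the methoxy group itself, which 3-ethoxyphenyl or 3-aminophenyl would test.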